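Swapping the aryl substituents in a cell-growth series

The source may report more compounds than this note shows. Statements on the series, on what has been measured and on what is new or still open speak of the compounds shown alone.

Compound 1 `CN(C)CCn1c(=O)c(=Cc2ccc(F)cc2F)s/c1=C1\C(=O)Nc2cc(F)ccc21` and compound 2 `CN(C)CCn1c(=O)c(=Cc2ccc(C=O)c(C=O)c2)s/c1=C1\C(=O)Nc2cc(F)ccc21` share one core and differ only in the aryl group on the double-bonded chain carbon. Going by the values given here, in a functional assay on MDA-MB-231 cells (Homo sapiens) for inhibition, read by MTT assay, with a stated time of 72 h (on this read-out lower numbers stand for stronger inhibition and higher numbers for weaker inhibition), compound 1 gives 8440 nM, and compound 2 gives 2420 nM, the lowest of the two numbers so far; the step of a 3.5-fold lower number from compound 1 to compound 2 (0.54 log units; beyond the scatter) lies beyond the scatter. Compound 3 `COc1ccc(OC)c(C=c2s/c(=C3\C(=O)Nc4cc(F)ccc43)n(CCN(C)C)c2=O)c1` carries the change (2,5-dimethoxyphenyl in place of 3,4-diformylphenyl on a double-bonded chain carbon bound to an aromatic carbon). Among the compounds with values here, the only measured step that bears on this position is a 3.5-fold lower number from compound 1 to compound 2 (0.54 log units; beyond the scatter), which shows that exchanging the aryl substituents moves this assay by a modest amount; no step speaks to methoxy groups directly. A return toward the number of compound 1 is therefore as plausible as a further fall, and the expectation is a moderate rise from compound 2, a 1.9-fold higher number from compound 2 to compound 3 (0.27 log units; within the scatter). Compound 3 is estimated at 4500 nM in this assay, with a range from 1500 nM to 13000 nM.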

Compound 3, half-maximal inhibitory concentration: 14500 nM
The estimate for compound 3 lay 3.2-fold (0.51 log units) below the measured number, outside the stated range (above it).
By their numbers in this assay, from the lowest: compound 2; then compounds 1 and 3 (each within the scatter of the next).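

In this assay the exchange of 3,4-diformylphenyl for 2,5-dimethoxyphenyl brings a 6.0-fold higher number from compound 2 to compound 3 (0.78 log units; beyond the scatter) and so shows that this position can move the number upward as well as downward, even though both groups have the same counts of heavy atoms and hydrogen-bond acceptors. The comparison with the first aryl group gives a 1.7-fold higher number from compound 1 to compound 3 (0.24 log units; within the scatter) and stays within the scatter, so 2,5-dimethoxyphenyl and 2,4-difluorophenyl cannot be told apart here, and among these three compounds only the 3,4-diformylphenyl group stands apart. Nothing available explains this difference.

The compounds shown leave open whether the lower number of compound 2 depends on having both formyl groups or would survive with only one. They also leave open what a phenyl ring bearing a carboxylic acid or an amine would do at this position.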